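A Bicyclic Carbonyl Group in Place of Fluoropiperidine

A few compounds are considered here, and "the series" means these few. Any claim that something is new, unique, unknown or untested is made for them only; others in the source may bear on it.

compound 1 `Cc1cccc(-c2noc(C3CN(S(=O)(=O)c4cccc(C)c4)C3)n2)c1`: > 10000 nM
compound 2 `O=C(N1CCC(F)CC1)N1CC(c2nc(-c3cccc(Cl)c3)no2)C1`: 990 nM

In an assay on HEK293 cells for positive allosteric modulation of metabotropic glutamate receptor 5 (Homo sapiens), read by FLIPR (on this read-out higher numbers stand for an effect only at larger amounts of compound and lower numbers for an effect already at smaller amounts), compound 1 gives > 10000 nM, which is a limit of the assay and not a number, the case described by the limit of > 10000 nM in this assay, at which 1 of the 2 values shown sits. Within the data shown here, compound 2 gives 990 nM in this assay, the only number among the two values shown. Among the measured compounds shown here, the two measured compounds differ in more than one place, so no single step between them can be drawn.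

Compound 3 `O=C([C@H]1CC2CCC1C2)N1CC(c2nc(-c3cccc(Cl)c3)no2)C1` has not yet been measured. It differs from compound 2 in one place: a group of 7 heavy atoms (7 carbon; 2 five-membered non-aromatic rings of carbon only) in place of a group of 7 heavy atoms (5 carbon, 1 nitrogen, 1 fluorine; one six-membered non-aromatic ring with 1 hetero atom), on a carbonyl carbon. For the measured compounds named here, both groups carry no hydrogen-bond donors or acceptors and match in heavy-atom count, and no measured step covers such a change. The step of a 1.4-fold lower number from compound 2 to compound 3 (0.15 log units; within the scatter) is therefore expected to remain within the usual scatter. Compound 3 is expected to give 700 nM in this assay, with a range from 200 nM to 3000 nM.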

Compound 3, half-maximal effective concentration: 74 nM
Beside the measured number, compound 3's estimate is 9.5-fold (0.98 log units) above it, outside the stated range (below it).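

In this assay, among these compounds, the group on this carbonyl carbon matters far more than the earlier compounds could show: replacing 4-fluoropiperidin-1-yl with the bicyclic all-carbon group gives a 13-fold lower number from compound 2 to compound 3 (1.13 log units; beyond the scatter). The heavy-atom count and the hydrogen-bond donor and acceptor counts are the same for both groups, so these counts do not separate compound 2 from compound 3. No measurement shown here bears on the reason for this step.

The compounds shown leave open how a cyclohexyl group or an unsubstituted piperidin-1-yl would read on the same carbonyl carbon, so the roles of the ring nitrogen, the fluorine and the two-ring form cannot be told apart. Going by these compounds, whether the defined stereocentre of the new group contributes to the step also remains open.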